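The source may hold more compounds than are shown below. What is called first, only, known or untested is meant among the compounds shown, and "the series" means these compounds.

Three compounds of the series have numbers in a functional assay on YAC-1 cells (Mus musculus); on this read-out higher numbers stand for larger maximal responses and lower numbers for smaller maximal responses. Compound 1 `Nc1nc(O)c2c(n1)n(C1OC(CO)[C@@H](O)[C@H]1O)c(=O)n2Cc1ccc(Cl)cc1` gives 27% in this assay and stands highest of the three. Compound 2 `C=CCn1c(=O)n([C@@H]2O[C@H](CO)[C@H]3OC(C)(CCC(=O)O)O[C@H]32)c2nc(N)nc(O)c21` gives 0% in this assay, and compound 3 `C=CCn1c(=O)n(C2OC(CO[Si](C)(C)C(C)(C)C)[C@@H](O)[C@H]2O)c2nc(N)nc(O)c21` gives 6% in this assay. The gap from compound 1 to compound 3 is beyond the scatter, as is the gap from compound 1 to compound 2; the gap between compound 2 and compound 3 is within it. Going by the values given here, no two of the measured compounds differ in only one place, so no measured step stands behind the change that leads to compound 4.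

Compound 4 `N#Cc1cccc(Cn2c(=O)n(C3OC(CO)[C@@H](O)[C@H]3O)c3nc(N)nc(O)c32)c1` is not yet measured in this assay. It differs from compound 1 in one place: 3-cyanophenyl in place of 4-chlorophenyl on a saturated chain carbon bound to an aromatic nitrogen. Both groups are single six-membered aromatic rings of carbon only; the group that enters carries one hydrogen-bond acceptor where the group that leaves carries none.

Among the compounds with values here, the series gives no step of this kind to go by. The number of compound 1 is modest, and the two other measured compounds, which differ from compound 1 in several places, sit lower. The expected step of a number 9 percentage points lower from compound 1 to compound 4 (within the scatter) is downward but not clearly beyond the scatter. Compound 4 is therefore expected to give 18% in this assay, within a range from 5% to 35%.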

Compound 4, largest response reached (reported as maximal response), in percent of the reference or control that the assay uses: 11%
For compound 4 the middle estimate is 7 percentage points above the measured one; the measured number falls inside the stated range.
By their numbers in this assay, from the lowest: compounds 2, 3 and 4 (each within the scatter of the next, the first and the last beyond it); then compound 1.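

In this assay, going by these compounds alone, the change from 4-chlorobenzyl to 3-cyanobenzyl gives the only single-place step, and it reads a number 16 percentage points lower from compound 1 to compound 4 (beyond the scatter) on the saturated chain carbon bound to an aromatic nitrogen. This shows that the maximal response depends on the group at this place, even when a six-membered aromatic ring of carbon only is kept and the rest of compound 1 stays unchanged. The step combines a change of substituent with a change of its place on the ring, and no measured data bear on why the response differs.

As far as these compounds go, it remains open whether the step follows from the loss of the chlorine, the arrival of the nitrile or the new place of the substituent, and an unsubstituted benzyl group would give a common reference for both compounds. Also open, from the compounds shown here alone, is how far this place tolerates other groups, such as a benzyl group carrying an amine or a carboxylic acid, or a longer chain between the aromatic ring and the core.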